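The source may report more compounds than this note shows. Statements on the series, on what has been measured and on what is new or still open speak of the compounds shown alone.

Measured in an ADME assay on microsomes from liver (Homo sapiens) for metabolic stability, read by LC-MS, with a stated time of 30 min, tested at 1 uM; on this read-out higher numbers stand for fast clearance and lower numbers for slow clearance:
Compound 1 `Fc1ccc(-c2ccc3nnc(Cc4ccc5ncccc5c4)n3n2)cc1F`: 13.4 mL.min-1.g-1
Compound 2 `C[C@@H](c1c[nH]c2ncccc12)c1nnc2ccc(-c3ccc(C#N)cc3)nn12`: 28 mL.min-1.g-1
Compound 3 `Nc1ccc2nnc(Cc3ccc4ncccc4c3)n2n1`: < 7.6 mL.min-1.g-1 (a limit)

Compound 3 gives < 7.6 mL.min-1.g-1, which is a limit of the assay and not a number. It is the only such case here: the limit of < 7.6 mL.min-1.g-1 in this assay, at which 1 of the 3 values shown sits.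

Compound 4 `CN(C)c1ccc2nnc(Cc3ccc4ncccc4c3)n2n1` has not yet been measured, and it differs from compound 3 in one place: dimethylamino in place of amino on an aromatic carbon. Within the data shown here, only one measured step touches that carbon: an at least 1.7-fold lower number from compound 1 to compound 3 (0.24 log units; that floor lies within the scatter). That step exchanges a different group, so it offers only indirect guidance on dimethylamino in place of amino. Among the measured compounds shown here, compound 2 differs in more than one place and gives no direct step.

The expectation therefore rests mainly on compound 1, which gives 13.4 mL.min-1.g-1 with another group on that carbon. The expected step in this assay is an at least 1.4-fold higher number from compound 3 to compound 4 (0.16 log units; that floor lies within the scatter), a modest rise that may not clear the scatter. For compound 4 the estimated value is 11 mL.min-1.g-1, with an expected range from 6 mL.min-1.g-1 to 25 mL.min-1.g-1.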

Compound 4, intrinsic clearance in microsomes in the Homo sapiens assay: 35 mL.min-1.g-1
Compound 4: the middle estimate sits 3.2-fold (0.50 log units) below what was measured; the whole stated range lies below it.
By their numbers in the Homo sapiens assay, from the lowest: compound 1; then compounds 2 and 4 (each within the scatter of the next). At a limit, below all of these: compound 3.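

In the Homo sapiens assay, dimethylamino in place of amino on this aromatic carbon gives an at least 4.6-fold higher number from compound 3 to compound 4 (0.66 log units; beyond the scatter). In a physicochemical assay for solubility, measured as kinetic solubility, at pH 6.5 (on this read-out lower numbers stand for lower solubility and higher numbers for higher solubility), compound 3 gives 453000 nM and compound 4 gives 134000 nM. In the physicochemical assay the same change gives a 3.4-fold lower number from compound 3 to compound 4 (0.53 log units; beyond the scatter), so this carbon responds in both read-outs to an exchange of only a few atoms. Compound 3 stands at a limit of the assay and not at a number: the limit of < 7.6 mL.min-1.g-1 in the Homo sapiens assay, at which 1 of the 4 values shown sits. In the Homo sapiens assay, dimethylamino in place of 3,4-difluorophenyl gives a 2.6-fold higher number from compound 1 to compound 4 (0.42 log units; beyond the scatter), so on this carbon the higher number goes with dimethylamino rather than with the aryl group, which the step between compound 1 and compound 3 alone could not show.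

The compounds shown leave open where a methylamino group or a morpholine on this carbon would fall relative to compound 3 and compound 4. They also leave open whether the two read-outs would move together across such amines.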